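Swapping the ring-nitrogen substituent on a thienopyridine amide

The source may hold more compounds than are shown below. What is called first, only, known or untested is meant among the compounds shown, and "the series" means these compounds.

Measured compounds:
- Compound 1, `NC(=O)c1c(NC(=O)c2ccccc2Cl)sc2c1CCN(Cc1ccc([N+](=O)[O-])cc1)C2`: 11400 nM
- Compound 2, `NC(=O)c1c(NC(=O)c2ccccc2Cl)sc2c1CCN(C(=S)Nc1ccccc1)C2`: 5940 nM

In a functional assay on HL-60 cells (Homo sapiens) for antiproliferative activity, with a stated time of 24 h (on this read-out higher numbers stand for weaker inhibition and lower numbers for stronger inhibition), compound 1 gives 11400 nM and compound 2 gives 5940 nM. Within the data shown here, the only step so far, a 1.9-fold lower number from compound 1 to compound 2 (0.28 log units; within the scatter), concerns the substituent on the amine nitrogen in the ring; the two compounds therefore cannot be set apart on this assay. Compound 3, `NC(=O)c1c(NC(=O)c2ccccc2Cl)sc2c1CCN(C(=O)Nc1ccccc1Cl)C2`, has not yet been measured. It differs from compound 2 by a group of 10 heavy atoms (7 carbon, 1 nitrogen, 1 oxygen, 1 chlorine; one six-membered aromatic ring of carbon only) in place of a group of 9 heavy atoms (7 carbon, 1 nitrogen, 1 sulfur; one six-membered aromatic ring of carbon only), on an amine nitrogen in a ring. Among the measured compounds shown here, no measured step covers this particular exchange; the one step at the same position was within the scatter. The step from compound 2 to compound 3 is accordingly expected to be a 1.0-fold higher number from compound 2 to compound 3 (0.00 log units; within the scatter), not beyond the scatter. Compound 3 is estimated to give 6000 nM, with a range from 2500 nM to 15000 nM.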

Compound 3, half-maximal inhibitory concentration: 12500 nM
The estimate for compound 3 lay 2.1-fold (0.32 log units) below the measured number, and the stated range covers the measured number.
By their numbers in this assay, from the lowest: compounds 2, 1 and 3 (each within the scatter of the next, the first and the last beyond it).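

In this assay, the exchange on the amine nitrogen in the ring now produces a step beyond the scatter, though a modest one: a 2.1-fold higher number from compound 2 to compound 3 (0.32 log units; beyond the scatter). The position is therefore not shown to be indifferent to its substituent, yet (2-chlorophenyl)carbamoyl and 4-nitrobenzyl still cannot be set apart, with a 1.1-fold higher number from compound 1 to compound 3 (0.04 log units; within the scatter) lying within the scatter. Nothing measured here offers an explanation for the step.

As far as these compounds go, the exchange from compound 2 to compound 3 puts oxygen in place of sulfur and brings in a chlorine at the same time, so the share of each in the step remains open. From the compounds shown here alone, it is also open how an acetyl group, a longer alkyl chain or a carboxylic acid on this ring nitrogen would compare.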